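The source may hold more compounds than are shown below. What is called first, only, known or untested is meant among the compounds shown, and "the series" means these compounds.

Measured compounds:
- compound 1, `O=C(CCCCCCNC(=O)C(O)(O)C(F)(F)F)Nc1nc2ccccc2s1`, 2370 nM
- compound 2, `NC(=O)C(=O)NCCCCCC(=O)Nc1ccccc1`, > 100000 nM
- compound 3, `COc1ccc2sc(NC(=O)CCCCCCNC(=O)C(O)(O)C(F)(F)F)nc2c1`, 2180 nM

In a functional assay on HCT-116 cells (Homo sapiens) for inhibition, read by colorimetric assay, with a stated time of 3 days (a lower number here means a stronger inhibitor, a higher number a weaker inhibitor), compound 1 gives 2370 nM, the higher of the two numbers recorded. Its nearest neighbour is compound 3, and the step of a 1.1-fold lower number from compound 1 to compound 3 (0.04 log units; within the scatter), a methoxy in place of hydrogen on an aromatic carbon, stays within the scatter. Going by the values given here, compound 2 gives only a limit, > 100000 nM, and stands at the limit of > 100000 nM in this assay, at which 1 of the 3 values shown sits; it differs from compound 1 in more than one place, so no single step links the two.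

Compound 4, `O=C(CCCCCCNC(=O)C(O)(O)C(F)(F)F)Nc1ccc(F)cc1`, has not yet been measured. It differs from compound 1 by 4-fluorophenyl in place of 1,3-benzothiazol-2-yl on an amide-type nitrogen, the 4-fluorophenyl entering on the amide-type nitrogen whose other neighbour is the carbonyl carbon. Among the compounds with values here, none of the measured steps touches this part of the molecule: the only single-place step recorded, from compound 1 to compound 3, changes a substituent on the departing ring system and is flat. Within the data shown here, no measured step therefore sets the size of this one. The account expects compound 4 to be weaker than compound 1, with an estimated step of a 3.8-fold higher number from compound 1 to compound 4 (0.58 log units; beyond the scatter) in the direction of a higher number. Compound 4 is thus estimated at 9000 nM, within a range from 2500 nM to 40000 nM.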

Compound 4, half-maximal inhibitory concentration: 7570 nM
For compound 4 the middle estimate is 1.2-fold (0.08 log units) above the measured one, and the stated range covers the measured number.
By their numbers in this assay, from the lowest: compounds 3 and 1 (each within the scatter of the next); then compound 4. At a limit, above all of these: compound 2.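

In this assay, the place on the amide-type nitrogen responds to a change of the group it carries: exchanging 1,3-benzothiazol-2-yl for 4-fluorophenyl gives a 3.2-fold higher number from compound 1 to compound 4 (0.50 log units; beyond the scatter), a modest step, whereas the methoxy change on the ring of compound 1 gave a 1.1-fold lower number from compound 1 to compound 3 (0.04 log units; within the scatter). The 1,3-benzothiazol-2-yl group is also not needed for a measurable number, since compound 4 with a single six-membered aromatic ring still gives 7570 nM in this assay. Nothing measured here accounts for the size of this step.

The step removes the five-membered aromatic ring with its two hetero atoms and brings in fluorine in one change, so the compounds shown do not separate the effect of the ring from that of the fluorine. From the compounds shown here alone, a plain phenyl or a pyridine ring on the same nitrogen, or a methoxy or chlorine in place of the fluorine, would be needed to tell these apart, and how far a longer chain would shift the number with either ring system remains open.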